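Phenyl to cyclohexyl on the shared core: expected effect

The source may report more compounds than this note shows. Statements on the series, on what has been measured and on what is new or still open speak of the compounds shown alone.

Measured compounds:
compound 1 `C[C@H](CC(=O)NC(=N)NCCCc1c[nH]cn1)c1ccccc1` gives 120 nM in an in vitro functional assay on Sf9 cells for agonist activity at histamine H2 receptor (Homo sapiens), read by GTPgammaS binding; a higher number here means that more compound is needed for the effect, a lower number that less compound is needed
compound 2 `Cc1nc(N)sc1CCCNC(=N)NC(=O)CC(C)c1ccccc1` gives 50.1 nM in this assay
compound 3 `C[C@@H](CC(=O)NC(=N)NCCCc1c[nH]cn1)c1ccccc1` gives 79.4 nM in this assay

Compound 2 gives the lowest of the three numbers shown in this assay. Its gap to compound 3 is within the scatter; only its gap to compound 1 lies beyond it.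

Going by the values given here, the single measured step, a 1.5-fold lower number from compound 1 to compound 3 (0.18 log units; within the scatter), concerns the drawing of a stereocentre on the saturated chain carbon the fact that one of compounds 1 and 3 is drawn with a defined configuration and the other without, at the place where they differ and is within the scatter. It does not touch the ring that is exchanged here.

Compound 4 `Cc1nc(N)sc1CCCNC(=N)NC(=O)CC(C)C1CCCCC1` differs from compound 2 by cyclohexyl in place of phenyl on a saturated chain carbon bound to two saturated chain carbons. Among the compounds with values here, no measured step bears on this change, so there is no measured basis for a step in either direction. The expectation for compound 4 in this assay is therefore a number close to that of compound 2, with no step beyond the scatter predicted, and a wide range to reflect the absence of a comparable step.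

Compound 4 is estimated at 60 nM in this assay, within 20 nM to 200 nM. This estimate means a step of a 1.2-fold higher number from compound 2 to compound 4 (0.08 log units; within the scatter), which is expected to stay within the scatter.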

Compound 4, half-maximal effective concentration: 9.33 nM
Compound 4: middle estimate off by 6.4-fold (0.81 log units), on the high side, outside the stated range (below it).
By their numbers in this assay, from the lowest: compound 4; then compounds 2, 3 and 1 (each within the scatter of the next, the first and the last beyond it).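

Cyclohexyl in place of phenyl on a saturated chain carbon bound to two saturated chain carbons gives a 5.4-fold lower number from compound 2 to compound 4 (0.73 log units; beyond the scatter) in this assay, the first measured step at this ring. An aromatic ring at this place is therefore not needed for a low number on the core of compound 2, and the non-aromatic ring of carbon only is the better of the two here. Nothing available bears on why the exchange has this effect.

On these data alone, whether the same exchange gives a step of similar size on the core of compound 1 remains open, as does how each configuration of the stereocentre behaves on the core of compound 4. Also open, as far as these compounds go, is how far the trend extends to other groups at this place, such as cyclopentyl, piperidine or a longer chain ending in cyclohexyl.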